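The compounds below may be only part of what the source reports. "The series", "measured", "known", "first", "only" and "open" are said of these compounds alone.

Measured compounds in a functional assay on KYSE-410 cells (Homo sapiens) for antiproliferative activity, read by MTT assay, with a stated time of 72 h; a higher number here means a weaker inhibitor, a lower number a stronger inhibitor:
- compound 1 `O=C(Nc1cccc(F)c1)c1cc(=O)[nH]c2cc(-c3cccc(F)c3)ccc12`: 10900 nM
- compound 2 `O=C(Nc1cccc(F)c1)c1cc(=O)[nH]c2cc(-c3ccc(F)nc3)ccc12`: > 20000 nM

Compound 2 gives > 20000 nM, which is a limit and not a number. It therefore stands at the limit of > 20000 nM in this assay, at which 1 of the 2 values shown sits, so its true position is not known.

Compound 3 `O=C(Nc1cccc(F)c1)c1cc(=O)[nH]c2cc(-c3ccc(F)c(CO)c3)ccc12` has not yet been measured in this assay. It carries 4-fluoro-3-(hydroxymethyl)phenyl in place of 6-fluoropyridin-3-yl on an aromatic carbon.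

For the measured compounds named here, only one measured step bears on this change, an at least 1.8-fold higher number from compound 1 to compound 2 (0.26 log units; that floor lies within the scatter). It concerns the same place on the shared core, but it is bounded on one side only. Going by the values given here, no measured compound shows what the hydroxymethyl group does on its own.

Compound 1, whose aromatic ring at this place is of carbon only, gives 10900 nM. Compound 3 also has a ring of carbon only there, so a modest move towards a lower number is expected, with a real chance that it stays at the limit.

The expected step is an at least 2.2-fold lower number from compound 2 to compound 3 (0.34 log units; beyond the scatter). For compound 3 the estimated value is 9000 nM, with an expected range from 2500 nM to 20000 nM.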

Compound 3, half-maximal inhibitory concentration: > 20000 nM
Compound 3 ended at the assay's limit; the forecaster's own chance of this, stated with the estimate: 25%; middle value at least 2.2-fold (0.34 log units) from the limit.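

In this assay compound 3 gives > 20000 nM, which is a limit and not a number. For the compounds shown here, the one step that can be read is an at least 1.8-fold higher number from compound 1 to compound 3 (0.26 log units; that floor lies within the scatter), on placing 4-fluoro-3-(hydroxymethyl)phenyl where 3-fluorophenyl stood; its floor lies within the scatter, so it sets no firm size, but it shows that a ring of carbon only at this place does not by itself keep a compound within the range of the assay. The steps between compound 2 and compound 3 cannot be read, because both compounds end at the same limit: the limit of > 20000 nM in this assay, at which 2 of the 3 values shown sit.

The compounds shown leave open how far compound 2 and compound 3 lie from that limit, and whether the hydroxymethyl group or the changed place of the fluorine decides the outcome in compound 3. They also leave open whether an amine or a carboxylic acid in place of the hydroxymethyl group would give a readable value in this assay.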